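Replacing 4-Fluorophenyl by Methoxy on a Carbonyl Carbon

A few compounds are considered here, and "the series" means these few. Any claim that something is new, unique, unknown or untested is made for them only; others in the source may bear on it.

Three compounds have been measured:
compound 1, `CC1(C)[C@H](C(=O)OC(c2ccccc2)c2ccccc2)N2C(=O)/C(=C/C(=O)c3ccc([N+](=O)[O-])cc3)[C@H]2[S+]1[O-]`, gives 48200 nM;
compound 2, `CC1(C)S[C@@H]2/C(=C\C(=O)c3ccc(F)cc3)C(=O)N2[C@H]1C(=O)OC(c1ccccc1)c1ccccc1`, gives 17800 nM;
compound 3, `CCOC(=O)/C=C1/C(=O)N2[C@@H]1SC(C)(C)[C@@H]2C(=O)OC(c1ccccc1)c1ccccc1`, gives 7000 nM.

All three were tested in a functional assay on A-375 cells (Homo sapiens) for cytotoxicity, read by MTT assay, with a stated time of 48 h; a higher number here means a weaker inhibitor, a lower number a stronger inhibitor. Among them compound 2 stands second highest of the three numbers. Its nearest neighbour is compound 3, reached by the step of a 2.5-fold lower number from compound 2 to compound 3 (0.41 log units; beyond the scatter). Within the data shown here, compound 1, which carries a different group in the same part of the molecule, gives the highest number of the set; since no single-point step links it to compound 2, only the two values themselves can be compared, and compound 1 sits at the weak end.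

The new compound 4, `COC(=O)/C=C1/C(=O)N2[C@@H]1SC(C)(C)[C@@H]2C(=O)OC(c1ccccc1)c1ccccc1`, differs from compound 2 as follows: methoxy in place of 4-fluorophenyl on a carbonyl carbon. Among the measured compounds shown here, the one measured step that bears on this is the change from compound 2 to compound 3, where ethoxy in place of 4-fluorophenyl on a carbonyl carbon gave a 2.5-fold lower number from compound 2 to compound 3 (0.41 log units; beyond the scatter). Compound 4 differs from compound 3 only in the length of the alkoxy chain, so a step of much the same size and direction is expected: a 2.4-fold lower number from compound 2 to compound 4 (0.38 log units; beyond the scatter). Compound 4 is therefore estimated at 7500 nM in this assay, with a plausible range from 3500 nM to 16000 nM.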

Compound 4, half-maximal inhibitory concentration: 24600 nM
For compound 4 the middle estimate is 3.3-fold (0.52 log units) below the measured one, and the stated range ends below it.
By their numbers in this assay, from the lowest: compound 3; then compounds 2, 4 and 1 (each within the scatter of the next, the first and the last beyond it).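

In this assay, among these compounds, methoxy in place of 4-fluorophenyl on a carbonyl carbon gives a 1.4-fold higher number from compound 2 to compound 4 (0.14 log units; within the scatter) and so leaves the number within the scatter even though an aromatic ring is lost, whereas ethoxy at the same place gave a 2.5-fold lower number from compound 2 to compound 3 (0.41 log units; beyond the scatter) as the only earlier reading of this change. The two alkoxy groups therefore do not read alike at this position: going from ethoxy to methoxy gives a 3.5-fold higher number from compound 3 to compound 4 (0.55 log units; beyond the scatter) and shows that the lower number of compound 3 cannot be credited to the loss of 4-fluorophenyl alone. Among compounds 2, 3 and 4, that lower number goes with ethoxy only, and nothing at hand explains the difference between the two alkoxy groups.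

The compounds shown leave open whether a propoxy group or a longer chain on this carbonyl carbon would follow ethoxy or return to the level of methoxy. They also leave open how an amine or a hydroxy group at the same carbon would read in this assay and whether the gap between ethoxy and methoxy would hold on other cell lines.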